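Adding a Methoxy Group to the Benzoyl Ester

The compounds below may be only part of what the source reports. "The series", "measured", "known", "first", "only" and "open" are said of these compounds alone.

Of the compounds shown here, two have so far been measured. In a functional assay on HeLa cells (Homo sapiens) for cytotoxicity, read by sulforhodamine B assay, with a stated time of 72 h (on this read-out lower numbers stand for stronger inhibition and higher numbers for weaker inhibition), compound 1 `C=C1C(=O)O[C@@H]2CC(C)=C([C@@H](C)CCCOC(C)=O)[C@@H](OC(=O)COc3cccc4[nH]nnc34)[C@H]12` gives 23000 nM, and compound 2 `C=C1C(=O)O[C@@H]2CC(C)=C([C@@H](C)CCCOC(C)=O)[C@@H](OC(=O)c3ccccc3)[C@H]12` gives 5190 nM, the lower of the two numbers; the step of a 4.4-fold lower number from compound 1 to compound 2 (0.65 log units; beyond the scatter) separates them. Compound 3 `C=C1C(=O)O[C@@H]2CC(C)=C([C@@H](C)CCCOC(C)=O)[C@@H](OC(=O)c3ccc(OC)cc3)[C@H]12` differs from compound 2 only in methoxy in place of hydrogen on an aromatic carbon. Within the data shown here, the single measured step exchanged one whole aromatic group for another on the carbonyl carbon; no measured pair adds a small group to the benzoyl ring of compound 2, so that step offers little direct guidance. With no such comparison available, the change is expected to leave the number for compound 3 close to that of compound 2, with no step beyond the scatter. The expected step is therefore a 1.0-fold lower number from compound 2 to compound 3 (0.02 log units; within the scatter). Compound 3 is estimated at 5000 nM, with a range from 1800 nM to 14000 nM.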

Compound 3, half-maximal inhibitory concentration: 8850 nM
Compound 3: middle estimate off by 1.8-fold (0.25 log units), on the low side, and the stated range covers the measured number.
By their numbers in this assay, from the lowest: compounds 2 and 3 (each within the scatter of the next); then compound 1.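

In this assay, putting methoxy in place of hydrogen on the benzoyl ring, para to a large group, gives a change that stays within the scatter (a 1.7-fold higher number from compound 2 to compound 3 (0.23 log units; within the scatter)), so this first small addition to the ring cannot be told apart from no change at all. The methoxy-bearing ester also keeps a clear gap from the larger group of compound 1 (a 2.6-fold lower number from compound 1 to compound 3 (0.41 log units; beyond the scatter)), so the advantage seen for the plain benzoyl ester of compound 2 survives the addition, though the gap is modest. No measured evidence is available to explain this result. A single methoxy at one ring position leaves open whether an amine, a carboxylic acid or a longer chain there would shift the number beyond the scatter. As far as these compounds go, whether methoxy would behave the same at another ring position also remains open.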